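Replacing the chloroquinolinyl hydrazone arm of compound 2

The source may report more compounds than this note shows. Statements on the series, on what has been measured and on what is new or still open speak of the compounds shown alone.

Compound 2 `O=C(/C=N/Nc1ccnc2cc(Cl)ccc12)NCCCCCCCNc1ccnc2cc(Cl)ccc12` gives 1400 nM in a functional assay on MRC5 cells (Homo sapiens) for cytotoxicity, read by colorimetric assay and MTT assay; on this read-out higher numbers stand for lower toxicity in this test and lower numbers for higher toxicity in this test. Compound 1 `O=C(/C=N/OCc1ccc([N+](=O)[O-])cc1)NCCCCCCCNc1ccnc2cc(Cl)ccc12` gives 1700 nM in this assay, so the two numbers sit within the scatter of each other; the step of a 1.2-fold lower number from compound 1 to compound 2 (0.08 log units; within the scatter) is the only one measured in the series. Compound 3 `Cc1cc(N/N=C/C(=O)NCCCCCCCNc2ccnc3cc(Cl)ccc23)nc2c1c(C)nn2C` is not yet measured. Relative to compound 2 it carries a group of 12 heavy atoms (9 carbon, 3 nitrogen; one five-membered aromatic ring with 2 hetero atoms, one six-membered aromatic ring with 1 hetero atom) in place of a group of 11 heavy atoms (9 carbon, 1 nitrogen, 1 chlorine; one six-membered aromatic ring of carbon only, one six-membered aromatic ring with 1 hetero atom), on an amine nitrogen. For the measured compounds named here, the one measured step, from compound 1 to compound 2, swaps the group on the same side of the hydrazone linker and stays within the scatter. Going by the values given here, no measured step touches the entering group itself, so nothing in the numbers points to a shift in either direction. Compound 3 is therefore expected near 1600 nM in this assay, within a range of 600 nM to 4500 nM. The expected step of a 1.1-fold higher number from compound 2 to compound 3 (0.06 log units; within the scatter) is thus estimated to stay within the scatter.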

Compound 3, half-maximal cytotoxic concentration: 1800 nM
Compound 3: middle estimate off by 1.1-fold (0.05 log units), on the low side, and the stated range covers the measured number.
By their numbers in this assay, from the lowest: compounds 2, 1 and 3 (each within the scatter of the next).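

In this assay, for the compounds shown here, the change on the amine nitrogen whose other neighbour is the double-bonded nitrogen stays within the scatter (a 1.3-fold higher number from compound 2 to compound 3 (0.11 log units; within the scatter)), and this is the first measured replacement of the 7-chloroquinolin-4-yl group itself. In this pair, the chlorine and the carbon-only aromatic ring of that group are not required to keep the number in this range, since the entering group has neither, and has a five-membered aromatic ring with 2 hetero atoms instead. No supporting data bear on why the number holds.

Still open, going by these compounds, is whether a non-aromatic group on this amine nitrogen, such as a simple alkyl chain or one ending in a carboxylic acid, would move the number beyond the scatter. The compounds shown also leave open what a shorter chain in the shared core would do.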